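Replacing the styryl arm: compound 4 against compounds 1 to 3

The source may report more compounds than this note shows. Statements on the series, on what has been measured and on what is new or still open speak of the compounds shown alone.

Measured compounds:
Compound 1, `COC(=O)/C=C/c1cccc(N(Cc2ccc(/C=C/c3c(F)cccc3F)cc2)C(=O)C(C)C)c1`, 108 nM in an assay on isolated protein with Bile acid receptor (Homo sapiens) as the target; a lower number here means that less compound is needed, a higher number that more compound is needed for the effect.
Compound 2, `COC(=O)/C=C/c1cccc(N(Cc2ccc(/C=C/c3cccc(F)c3)cc2)C(=O)C(C)C)c1`, 71 nM.
Compound 3, `COC(=O)/C=C/c1cccc(N(Cc2ccc(/C=C/c3ccc(F)cc3)cc2)C(=O)C(C)C)c1`, 120 nM.

Compound 3 gives the highest number of the three, but its steps to the others are small: a 1.1-fold higher number from compound 1 to compound 3 (0.05 log units; within the scatter) and a 1.7-fold higher number from compound 2 to compound 3 (0.23 log units; within the scatter), both within the scatter, as is a 1.5-fold lower number from compound 1 to compound 2 (0.18 log units; within the scatter). Moving the fluorine around the phenyl at the far end of the double-bonded chain therefore leaves the result essentially unchanged.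

Compound 4, `COC(=O)/C=C/c1cccc(N(Cc2ccc(-c3ccc(SC)cc3)cc2)C(=O)C(C)C)c1`, is not yet measured. It differs from compound 3 in one place: 4-(methylsulfanyl)phenyl in place of 2-(4-fluorophenyl)ethenyl on an aromatic carbon. The change is placed on an aromatic carbon, para to a large group. None of the three measured steps bears on it directly, since all of them alter only the fluorine pattern on the same 2-(fluorophenyl)ethenyl arm; they show merely that this arm tolerates such shifts. On these data alone, the loss of the double-bonded chain and the entry of a sulfur-bearing acceptor are untested here, so the expectation is broad. Compound 4 is expected to give about 160 nM, with a range from 40 nM to 650 nM, implying an estimated step of a 1.3-fold higher number from compound 3 to compound 4 (0.12 log units; within the scatter) that may reach beyond the scatter in either direction.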

Compound 4, half-maximal effective concentration: 51 nM
The estimate for compound 4 lay 3.1-fold (0.50 log units) above the measured number, within the range that was stated.
By their numbers in this assay, from the lowest: compounds 4, 2, 1 and 3 (each within the scatter of the next, the first and the last beyond it).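

In this assay, the 2-(fluorophenyl)ethenyl arm on this aromatic carbon proves replaceable as a whole, which the fluorine shifts could not show: 4-(methylsulfanyl)phenyl, with no double bond outside the aromatic rings, keeps the number in the same range. The change gives a 2.4-fold lower number from compound 3 to compound 4 (0.37 log units; beyond the scatter) and a 2.1-fold lower number from compound 1 to compound 4 (0.33 log units; beyond the scatter), both modest, whereas a 1.4-fold lower number from compound 2 to compound 4 (0.14 log units; within the scatter), so its size depends on which fluorine pattern it is read against. No measurement shown here accounts for these steps.

On these data alone, whether the result belongs to the sulfur or to the aromatic ring joined directly at this place stays open, and a plain phenyl or a 4-methoxyphenyl group would separate the two. As far as these compounds go, how a carboxylic acid in place of the methyl ester would fare alongside this arm also remains open.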